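Swapping the aryl urea partner of compound 1 for a benzamide

The source may hold more compounds than are shown below. What is called first, only, known or untested is meant among the compounds shown, and "the series" means these compounds.

Measured compounds:
- compound 1, `COc1cc(Nc2ncnc3c(NC(=O)Nc4ccc(C)cc4C)cccc23)cc(OC)c1`: 1290 nM
- compound 2, `COc1cc(Nc2ncnc3c(NC(=O)Nc4ccc(F)cc4C(F)(F)F)cccc23)cc(OC)c1`: 2970 nM
- compound 3, `COc1cc(Nc2ncnc3c(NC(=O)Nc4ccc(Cl)cc4Cl)cccc23)cc(OC)c1`: 3060 nM

In a functional assay on RT-112 cells (Homo sapiens) for antiproliferative activity, read by MTT assay, with a stated time of 72 h (on this read-out higher numbers stand for weaker inhibition of growth and lower numbers for stronger inhibition of growth), compound 1 gives 1290 nM, the lowest of the three numbers. The step of a 2.3-fold higher number from compound 1 to compound 2 (0.36 log units; beyond the scatter) and the step of a 2.4-fold higher number from compound 1 to compound 3 (0.38 log units; beyond the scatter) are both modest and beyond the scatter, while the step of a 1.0-fold higher number from compound 2 to compound 3 (0.01 log units; within the scatter) lies within it. All three measured compounds keep the same shared core and the same carbonyl bridge; they differ only in the ring attached to the amide-type nitrogen.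

Compound 4, `COc1cc(Nc2ncnc3c(NC(=O)c4ccc(CN(C)C)cc4)cccc23)cc(OC)c1`, is not yet measured. It departs from compound 1 in another way: 4-((dimethylamino)methyl)phenyl in place of (2,4-dimethylphenyl)amino on a carbonyl carbon. Instead of a ring on a second nitrogen, the carbonyl carbon now carries the ring directly, and that ring bears a 4-((dimethylamino)methyl) group. Among the compounds with values here, none of the measured steps tests this kind of change, so they bear on it only indirectly: they show that altering the ring attached through the carbonyl moves this assay by modest amounts. On that basis no step beyond the scatter is expected in this assay, but with wide uncertainty. Compound 4 is estimated at 1500 nM, within 400 nM to 6000 nM, meaning an expected step of a 1.2-fold higher number from compound 1 to compound 4 (0.07 log units; within the scatter).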

Compound 4, concentration for 50% growth inhibition: 4370 nM
The estimate for compound 4 lay 2.9-fold (0.46 log units) below the measured number, and the stated range covers the measured number.
By their numbers in this assay, from the lowest: compound 1; then compounds 2, 3 and 4 (each within the scatter of the next).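

In this assay, replacing the (2,4-dimethylphenyl)amino group on the carbonyl carbon with 4-((dimethylamino)methyl)phenyl gives a 3.4-fold higher number from compound 1 to compound 4 (0.53 log units; beyond the scatter), so this position accepts a change to the link as well as to the ring, at a modest cost. A hydrogen-bond donor gives way to a hydrogen-bond acceptor here, yet growth inhibition does not disappear, and compound 4 cannot be told apart from the other two compounds, with a 1.4-fold higher number from compound 3 to compound 4 (0.15 log units; within the scatter) and a 1.5-fold higher number from compound 2 to compound 4 (0.17 log units; within the scatter). No measurement shown here explains the step from compound 1 to compound 4.

This single change removes the nitrogen link and adds the dimethylaminomethyl group at once, so its effects cannot be separated without a matching compound that changes only one of them, such as the 2,4-dimethylphenyl ring attached directly to the carbonyl carbon. From the compounds shown here alone, it also remains open how the assay would respond if a morpholine or a carboxylic acid took the place of the dimethylamino group on this ring.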